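This account rests on a few compounds, and the source may have more. Where it says the series, first, only, none or still open, it means among the compounds named here.

Compound 2 `C#CCSc1nc(NCCC#N)c2ccncc2n1` is one of three compounds examined in a functional assay on MGC-803 cells (Homo sapiens) for inhibition, read by MTT assay, with a stated time of 72 h; a lower number here means a stronger inhibitor, a higher number a weaker inhibitor. In this assay compound 2 gives > 80000 nM, which is a limit of the assay and not a number. Compound 1 `C#CCSc1nc(NCCC(C)C)c2ccncc2n1` likewise gives > 80000 nM, again a limit. Compound 3 `C#CCSc1nc(Nc2cccc(Cl)c2)c2ccncc2n1` gives 2190 nM. Owing to the limit of > 80000 nM in this assay, at which 2 of the 3 values shown sit, the step that the two limits leave unreadable from compound 1 to compound 2 cannot be read, whereas the step of an at least 36-fold lower number from compound 2 to compound 3 (1.56 log units; beyond the scatter) and the step of an at least 36-fold lower number from compound 1 to compound 3 (1.56 log units; beyond the scatter) are both large and run toward stronger inhibition.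

Compound 4 `C#CCSc1nc(N2CCN(C)CC2)c2ccncc2n1` has not yet been measured. It differs from compound 2 in one place: 4-methylpiperazin-1-yl in place of (2-cyanoethyl)amino on an aromatic carbon. The two large measured steps both brought a 3-chlorophenyl group onto the nitrogen on the aromatic ring, so they do not directly speak to a 4-methylpiperazin-1-yl group, which is a six-membered non-aromatic ring with no hydrogen-bond donor. With the two open-chain amines of compound 1 and compound 2 both sitting at the limit, the step of an at least 1.7-fold lower number from compound 2 to compound 4 (0.24 log units; that floor lies within the scatter) is expected to be small or absent. Compound 4 is therefore estimated to give 45000 nM, with a range from 8000 nM to 200000 nM.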

Compound 4, half-maximal inhibitory concentration: > 80000 nM
Compound 4 ended at the assay's limit; the forecaster's own chance of this, stated with the estimate: 55%; middle value at least 1.7-fold (0.24 log units) from the limit.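

In this assay compound 4 gives > 80000 nM, which is a limit and not a number. The steps to compound 4 from compound 1 and compound 2 cannot be read, because all three compounds sit at the same limit: the limit of > 80000 nM in this assay, at which 3 of the 4 values shown sit.

Still open, on these data alone, is how weak compound 1, compound 2 and compound 4 really are, and whether they differ at all.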